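Adding methoxy groups on a fused-ring amide series

A few compounds are considered here, and "the series" means these few. Any claim that something is new, unique, unknown or untested is made for them only; others in the source may bear on it.

Compound 1 `COc1ccc(-c2cc(C(=O)Nc3nc4ccc(F)cc4s3)nc3cc(-c4ccccc4)nn23)cc1` carries a 4-methoxyphenyl group, and in a functional assay on HeLa cells (Homo sapiens) for cytotoxicity, read by MTT assay, with a stated time of 48 h (a higher number here means a weaker inhibitor, a lower number a stronger inhibitor), compound 1 gives 41700 nM. Compound 2 `COc1ccc(-c2cc(C(=O)Nc3nc4ccc(F)cc4s3)nc3cc(-c4ccccc4)nn23)cc1OC` differs from it by methoxy in place of hydrogen on an aromatic carbon; in this assay compound 2 gives 8310 nM, a change of a 5.0-fold lower number from compound 1 to compound 2 (0.70 log units; beyond the scatter). Compound 3 `COc1ccc2nc(NC(=O)c3cc(-c4ccc(OC)c(OC)c4)n4nc(-c5ccccc5)cc4n3)sc2c1` has a different core; how its core differs from that of compound 1 is not broken down here. In this assay compound 3 gives 11000 nM, and the step of a 1.3-fold higher number from compound 2 to compound 3 (0.12 log units; within the scatter) lies within the scatter. Compound 4 `COc1ccc2nc(NC(=O)c3cc(-c4cc(OC)c(OC)c(OC)c4)n4nc(-c5ccccc5)cc4n3)sc2c1` is not yet measured; it differs from compound 3 by methoxy in place of hydrogen on an aromatic carbon. This is the same kind of change as that from compound 1 to compound 2, not the same one: here the place is also meta to a methoxy group (2 heavy atoms). A step in the same direction but somewhat smaller is expected, a 2.2-fold lower number from compound 3 to compound 4 (0.34 log units; beyond the scatter), because the earlier step of a 5.0-fold lower number from compound 1 to compound 2 (0.70 log units; beyond the scatter) was only modest and the surroundings of the place now differ. Compound 4 is therefore expected to give about 5000 nM, with a likely range from 1800 nM to 14000 nM.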

Compound 4, half-maximal inhibitory concentration: 8700 nM
The estimate for compound 4 lay 1.7-fold (0.24 log units) below the measured number; low and high end bracket the measured number.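

In this assay the step from 3,4-dimethoxyphenyl to 3,4,5-trimethoxyphenyl reads a 1.3-fold lower number from compound 3 to compound 4 (0.10 log units; within the scatter) and so cannot be told apart from the ordinary spread of repeated measurements. Adding a methoxy group to an aromatic carbon therefore did not carry over from one core to the other with the same size of effect: the same change on two cores in this assay, a 5.0-fold lower number (0.70 log units; beyond the scatter) from compound 1 to compound 2 and a 1.3-fold lower number (0.10 log units; within the scatter) from compound 3 to compound 4, 4.0-fold (0.60 log units) apart, beyond the scatter of two such steps. Among these compounds, this does not show why the two steps differ, since only two pairs are compared, and they differ both in the core and in how many methoxy groups the ring already carries.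

On these data alone, it remains open how a third methoxy group would behave on the core of compound 2, which would separate those two differences. Also open, as far as these compounds go, is whether a different group at this place on the ring, such as an amine or a carboxylic acid, would shift the number on either core.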